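Lengthening the alkyl sulfide chain on the shared core

This account rests on a few compounds, and the source may have more. Where it says the series, first, only, none or still open, it means among the compounds named here.

Compound 1 `CCCCSc1n[nH]c(-n2[se]c3ccccc3c2=O)n1` gives 32900 nM in a functional assay on HeLa cells (Homo sapiens) for antiproliferative activity, read by CCK-8 assay, with a stated time of 48 h; a higher number here means a weaker inhibitor, a lower number a stronger inhibitor.
Compound 2 `O=c1c2ccccc2[se]n1-c1nc(SCc2ccc(F)cc2)n[nH]1` reaches only the limit > 50000 nM in this assay.

Compound 2 thus stands at the limit of > 50000 nM in this assay, at which 1 of the 2 values shown sits, so no number is known for it, only that limit. Compound 3 `CCCCCSc1n[nH]c(-n2[se]c3ccccc3c2=O)n1` differs from it by butyl in place of 4-fluorophenyl on a saturated chain carbon bound to a sulfur. Within the data shown here, one measured step bears on this: an at least 1.5-fold higher number from compound 1 to compound 2 (0.18 log units; that floor lies within the scatter). Reversing that change should lead back toward compound 1, which gave 32900 nM. The expected step is therefore an at least 1.4-fold lower number from compound 2 to compound 3 (0.15 log units; that floor lies within the scatter). For compound 3 the estimate is 35000 nM, ranging from 15000 nM to 80000 nM.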

Compound 3, half-maximal inhibitory concentration: 30300 nM
Beside the measured number, compound 3's estimate is 1.2-fold (0.06 log units) above it; the range from low to high includes it.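

Adding a methyl in place of hydrogen on a saturated chain carbon, four bonds along the chain from a sulfur, gives a 1.1-fold lower number from compound 1 to compound 3 (0.04 log units; within the scatter), so this longer chain leaves the reading in this assay unchanged within the scatter. Pentyl in place of 4-fluorobenzyl gives an at least 1.6-fold lower number from compound 2 to compound 3 (0.21 log units; that floor lies within the scatter), so even this change of chain type is not shown to matter. Compound 2 has only a limit, not a number: the limit of > 50000 nM in this assay, at which 1 of the 3 values shown sits.

From the compounds shown here alone, whether a much longer chain such as octyl, or a chain ending in an amine, would move the number beyond the scatter remains open.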